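The compounds below may be only part of what the source reports. "The series", "measured", "known", "first", "only" and "open" are said of these compounds alone.

Working notes on the series. In a functional assay on MV4-11 cells (Homo sapiens) for antiproliferative activity, read by resazurin assay, with a stated time of 72 h (on this read-out higher numbers stand for weaker inhibition of growth and lower numbers for stronger inhibition of growth), compound 3 `CC(=O)N1CCN(c2ccc(Nc3nccc(-c4nn(C)c5ccccc45)n3)cc2)CC1` gives 181 nM, the highest of the two numbers shown. Compound 1 `CC(=O)N1CCN(c2ccc(Nc3ncc(C#N)c(-c4n[nH]c5ccccc45)n3)cc2)CC1` gives 17 nM in this assay. Compound 2 `CC(=O)N1CCN(c2ccc(Nc3nccc(-c4c[nH]c5ncccc45)n3)cc2)CC1` sits at the limit of this assay, (the limit of < 1 nM in this assay, at which 1 of the 3 values shown sits), reported as < 1 nM. Among the compounds with values here, the one measured step, an at least 180-fold higher number from compound 2 to compound 3 (2.25 log units; beyond the scatter), is large and runs toward weaker inhibition. Compound 4 `CC(=O)N1CCN(c2ccc(Nc3nccc(-c4n[nH]c5ccccc45)n3)cc2)CC1` differs from compound 3 by hydrogen in place of methyl on an aromatic nitrogen, so 1-methyl-1H-indazol-3-yl becomes 1H-indazol-3-yl. Within the data shown here, no measured step makes exactly this change, but compound 1 bears the same 1H-indazol-3-yl group and gives a far lower number than compound 3, and an at least 180-fold higher number from compound 2 to compound 3 (2.25 log units; beyond the scatter) moved the number strongly when this methyl entered. A large step back toward stronger inhibition is therefore expected, a 36-fold lower number from compound 3 to compound 4 (1.56 log units; beyond the scatter). For compound 4 the estimate in this assay is 5 nM, expected between 1 nM and 30 nM.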

Compound 4, concentration for 50% growth inhibition: 346 nM
Estimate against measurement, compound 4: 69-fold (1.84 log units) below, outside the stated range (above it).
By their numbers in this assay, from the lowest: compound 1; then compounds 3 and 4 (each within the scatter of the next). At a limit, below all of these: compound 2.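

Hydrogen and methyl on this aromatic nitrogen are not told apart in this assay: a 1.9-fold higher number from compound 3 to compound 4 (0.28 log units; within the scatter), so the large earlier step reflected the exchange of the whole group and not the methyl alone. The larger differences lie elsewhere: a 20-fold higher number from compound 1 to compound 4 (1.31 log units; beyond the scatter), with hydrogen in place of cyano on an aromatic carbon, and an at least 340-fold higher number from compound 2 to compound 4 (2.53 log units; beyond the scatter), with the group on the aromatic carbon exchanged. Compound 2 is a limit and not a number, so that last step is only a bound: the limit of < 1 nM in this assay, at which 1 of the 4 values shown sits.

The compounds shown leave open whether a longer chain or an amine on this aromatic nitrogen would give a number like those of compound 3 and compound 4, and what a carboxylic acid in place of cyano would give.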